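Pyrimidine series: pyridin-4-ylmethyl amine replacing cyclohexylmethyl

This account rests on a few compounds, and the source may have more. Where it says the series, first, only, none or still open, it means among the compounds named here.

Measured so far:
- compound 1 `CNc1nc(NCC(C)(C)C)cc(-c2ccccn2)n1`: 73 nM
- compound 2 `CNc1nc(NCC2CCCCC2)cc(-c2ccccn2)n1`: 11 nM

Among the compounds with values here, in a functional assay on HEK293 cells for agonist activity at G-protein coupled receptor 39 (Homo sapiens), read by inositol phosphate accumulation (on this read-out lower numbers stand for an effect already at smaller amounts and higher numbers for an effect only at larger amounts of compound), compound 2 holds the lowest of the two numbers; compound 1 is the only neighbour, and the step of a 6.6-fold lower number from compound 1 to compound 2 (0.82 log units; beyond the scatter) is beyond the scatter. The open question is compound 3 `CNc1nc(NCc2ccncc2)cc(-c2ccccn2)n1`, in which the change is pyridin-4-yl in place of cyclohexyl on a saturated chain carbon bound to a nitrogen on an aromatic ring. Within the data shown here, no measured pair covers a saturated ring giving way to an aromatic ring at this position; the single known step, a 6.6-fold lower number from compound 1 to compound 2 (0.82 log units; beyond the scatter), shows only that the group on this chain carbon moves the read-out by a modest amount. The difference here is of another kind and its direction is not fixed by the data; a step of similar size is plausible, and the expectation is that the number rises rather than falls. The estimated step is a 3.6-fold higher number from compound 2 to compound 3 (0.56 log units; beyond the scatter). Compound 3 is therefore expected at 40 nM in this assay, with a range from 10 nM to 160 nM.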

Compound 3, half-maximal effective concentration: 87 nM
Compound 3: middle estimate off by 2.2-fold (0.34 log units), on the low side; the measured number falls inside the stated range.
By their numbers in this assay, from the lowest: compound 2; then compounds 1 and 3 (each within the scatter of the next).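

In this assay the first change from a non-aromatic ring to an aromatic ring on this saturated chain carbon gives a 7.9-fold higher number from compound 2 to compound 3 (0.90 log units; beyond the scatter), so pyridin-4-yl does not stand in for cyclohexyl here even though both groups have 6 heavy atoms. Set against tert-butyl, pyridin-4-yl gives a 1.2-fold higher number from compound 1 to compound 3 (0.08 log units; within the scatter), which leaves cyclohexyl as the only one of the three groups apart from the other two on this read-out. No evidence at hand bears on the reason for this step.

Still open, as far as these compounds go, is whether the step follows the ring nitrogen of pyridin-4-yl or the aromatic ring as such, which a phenyl group on the same chain carbon would separate. Also open, from the compounds shown here alone, are how pyridin-3-yl compares with pyridin-4-yl and what a longer chain carrying cyclohexyl does.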